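This account rests on a few compounds, and the source may have more. Where it says the series, first, only, none or still open, it means among the compounds named here.

Compound 1 `CNc1nn2c(N)cc(C)nc2c1S(=O)(=O)c1cccc(Cl)c1`: 0.219 nM
Compound 2 `CNc1nn2c(N)c(Cl)c(C)nc2c1S(=O)(=O)c1ccccc1`: 0.141 nM; 0.14 nM (2 entries)

Among the compounds with values here, the two measured compounds share one core but differ from each other in two places at once, so no single-point step can be drawn between them. Within the data shown here, in a functional assay on HEK293 cells for inhibition of 5-hydroxytryptamine receptor 6 (Homo sapiens), read by cAMP accumulation (on this read-out lower numbers stand for stronger inhibition and higher numbers for weaker inhibition), compound 1 gives 0.219 nM, the one number available for it; a further entry for compound 1 reports no single number. Compound 2 gives 0.141 nM; 0.14 nM (2 entries), and its repeated entries agree closely (the several entries of compound 2 in this assay, 0.141 nM; 0.14 nM (2 entries)). The values of compound 1 and compound 2 lie within the usual scatter of each other, so neither can be set apart from the other on these numbers.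

Compound 3 `CNc1nn2c(N)c(Cl)c(C)nc2c1S(=O)(=O)c1cccc(Cl)c1` has not yet been measured in this assay. It differs from compound 1 by chloro in place of hydrogen on an aromatic carbon. Among the measured compounds shown here, no measured pair isolates this change, so its size must be estimated from the two measured compounds alone; since those sit close together, the expected step in this assay is small, none beyond the scatter, in either direction. Compound 3 is therefore expected to give about 0.16 nM, with a range from 0.07 nM to 0.4 nM. This estimate implies a step of a 1.4-fold lower number from compound 1 to compound 3 (0.14 log units; within the scatter) that is expected to stay within the scatter.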

Compound 3, inhibition constant: 18.6 nM
For compound 3 the middle estimate is 120-fold (2.07 log units) below the measured one; the whole stated range lies below it.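

In this assay, placing chloro on this aromatic carbon of compound 1, ortho to the methyl and amino groups, gives an 85-fold higher number from compound 1 to compound 3 (1.93 log units; beyond the scatter), so this position is not indifferent to substitution in the setting of compound 1. Within the data shown here, the change cannot be read as a penalty for chloro at this position alone: compound 2 carries the same chloro there and gives 0.141 nM; 0.14 nM (2 entries), whereas, with the further chlorine that it shares with compound 1 as its only difference from compound 2, compound 3 gives 18.6 nM. The size of the chloro step therefore depends on the rest of the molecule, at least across these three compounds, but nothing at hand bears on the cause of this step.

The compounds shown leave open whether the same sharp rise would follow with fluoro, bromo, methoxy or an amine at this position in place of chloro. They also leave open whether the dependence on the further chlorine holds when that chlorine is replaced by another group, such as methyl or trifluoromethyl.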